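Cyclohexylmethyl for Cyclohexylamino on a Carbonyl Carbon

This account rests on a few compounds, and the source may have more. Where it says the series, first, only, none or still open, it means among the compounds named here.

In a functional assay on A549 cells (Homo sapiens) for antiproliferative activity, read by MTT assay, with a stated time of 72 h (a lower number here means a stronger inhibitor, a higher number a weaker inhibitor), compound 1 `CCCNc1ccnc(Nc2ccc(NC(=O)Nc3ccc(Cl)c(C(F)(F)F)c3)cc2)n1` gives 7320 nM and compound 2 `O=C(Nc1ccc(Nc2nccc(NC3CCCC3)n2)cc1)NC1CCCCC1` gives 5320 nM, so the two values lie within the scatter of each other. Compound 3 `O=C(CC1CCCCC1)Nc1ccc(Nc2nccc(NC3CCCC3)n2)cc1` has yet to be measured. It carries cyclohexylmethyl in place of cyclohexylamino on a carbonyl carbon. Among the measured compounds shown here, no measured pair of compounds shows this change, and no step beyond the scatter is expected in this assay. The expected step is a 1.1-fold lower number from compound 2 to compound 3 (0.03 log units; within the scatter). For compound 3 the estimated value is 5000 nM, with an expected range of 2000 nM to 12500 nM.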

Compound 3, half-maximal inhibitory concentration: 3940 nM
For compound 3 the middle estimate is 1.3-fold (0.10 log units) above the measured one; the range from low to high includes it.
By their numbers in this assay, from the lowest: compounds 3, 2 and 1 (each within the scatter of the next).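

In this assay, among the compounds shown here, the step at this carbonyl carbon, a 1.4-fold lower number from compound 2 to compound 3 (0.13 log units; within the scatter), is the first direct comparison at this position. Cyclohexylmethyl removes the hydrogen-bond donor counted on cyclohexylamino, yet the two compounds cannot be told apart, so that donor shows no effect here beyond the scatter. No measurement is available that bears on the reason for this.

Left open is whether a cyclohexyloxy group, a piperidine or a longer chain on the same carbonyl carbon would read alike. From the compounds shown here alone, it also remains open whether any replacement there can produce a step beyond the scatter.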